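The compounds below may be only part of what the source reports. "The series", "measured", "known", "first", "only" and "open" are said of these compounds alone.

For the measured compounds named here, in an ADME assay on the whole organism (plasma) for pharmacokinetics, with Rattus norvegicus as the target, with a stated time of 6 h, at a dose of 10 mg/kg by the oral route (on this read-out lower numbers stand for lower exposure and higher numbers for higher exposure at the dose given), compound 1 (`CC(C)[C@]1(C)CC(=O)N(Cc2cc(F)cc(C(=O)N[C@@H](C)c3ccccc3)c2)C(=N)N1`) gives 2770 ng.h/mL and stands highest of the two numbers so far. Going by the values given here, compound 2 (`CC(C)[C@]1(C)CC(=O)N(Cc2ccnc(N3C[C@@H](c4ccccc4)CC3=O)c2)C(=N)N1`) gives 1020 ng.h/mL as the nearest number, a gap beyond the scatter, but it differs from compound 1 in more than one place and so offers no single-change step. Compound 3 (`CC(C)[C@]1(C)CC(=O)N(Cc2cccc(C(=O)N[C@@H](C)c3ccccc3)c2)C(=N)N1`) is not yet measured and differs from compound 1 in one place: hydrogen in place of fluoro on an aromatic carbon (hydrogen in place of fluoro on an aromatic carbon, meta to two large groups). Among the compounds with values here, no measured pair shows this change, so the expectation rests on the structural change alone. Expected in this assay is a 1.2-fold lower number from compound 1 to compound 3 (0.08 log units; within the scatter) (downward if anything, and none beyond the scatter). For compound 3 the estimate is 2300 ng.h/mL (expected range 1000 ng.h/mL to 5300 ng.h/mL).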

Compound 3, area under the concentration-time curve: 165 ng.h/mL
The estimate for compound 3 lay 14-fold (1.14 log units) above the measured number; measured number below the stated range.
By their numbers in this assay, from the lowest: compound 3; then compound 2; then compound 1.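

In this assay, hydrogen in place of fluoro on an aromatic carbon, meta to two large groups, gives a 17-fold lower number from compound 1 to compound 3 (1.22 log units; beyond the scatter). For the compounds shown here, this is the first single-change step, and it shows that this position is far from silent for oral exposure: the loss of one fluorine, with the rest of the structure unchanged, is enough for a large step. No data shown here bear on the reason for this step.

Going by these compounds, whether the step depends on fluoro itself or on having any group at this carbon remains open, and a chloro, methyl or nitrile group at the same place would separate the two. Going by these compounds alone, with only one such pair, it also remains open whether the same change would give a step of similar size in other members.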